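Pyridine in Place of Dichlorophenyl on the Amide

The source may hold more compounds than are shown below. What is called first, only, known or untested is meant among the compounds shown, and "the series" means these compounds.

Among the compounds with values here, compound 3 `O=C(Nc1ccc(Cl)c(-c2nnc3c(Cl)cccn23)c1)c1ccc(Cl)cc1Cl` is the one compound here with a number rather than a limit: in a functional assay on AN3-CA cells (Homo sapiens) for antiproliferative activity, read by MTT assay, with a stated time of 72 h (a higher number here means a weaker inhibitor, a lower number a stronger inhibitor), compound 3 gives 84800 nM. Compound 1 `O=C(Nc1ccc(Cl)c(-c2nnc3c(Cl)cccn23)c1)c1ccc(Cl)cc1` reaches only the limit of this assay, giving > 100000 nM. Compound 2 `Cc1cc(Cl)ccc1C(=O)Nc1ccc(Cl)c(-c2nnc3c(Cl)cccn23)c1` likewise stops at that limit, giving > 100000 nM. Compound 4 `O=C(Nc1ccc(Cl)c(-c2nnc3c(Cl)cccn23)c1)c1cccnc1Cl` differs from compound 3 by 2-chloropyridin-3-yl in place of 2,4-dichlorophenyl on a carbonyl carbon. The nearest measured steps are an at least 1.1-fold lower number from compound 1 to compound 3 (0.07 log units; that floor lies within the scatter) and an at least 1.1-fold lower number from compound 2 to compound 3 (0.07 log units; that floor lies within the scatter), both floors that sit within the scatter, since the limit of > 100000 nM in this assay, at which 2 of the 3 values shown sit, holds two of the three values. The step to compound 4 removes a chloro and brings a ring nitrogen, a change none of these steps covers, so no shift beyond the scatter is expected. Compound 4 is therefore estimated at 90000 nM in this assay, within 30000 nM to 300000 nM, meaning an expected 1.1-fold higher number from compound 3 to compound 4 (0.03 log units; within the scatter).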

Compound 4, half-maximal inhibitory concentration: > 100000 nM
Compound 4 ended at the assay's limit (the forecaster's own chance of this, stated with the estimate: 55%); at least 1.1-fold (0.04 log units) between middle value and limit.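

Replacing 2,4-dichlorophenyl with 2-chloropyridin-3-yl on the carbonyl carbon gives an at least 1.1-fold higher number from compound 3 to compound 4 (0.07 log units; that floor lies within the scatter), so this change shows no gain in this assay. The steps from compound 1 and compound 2 to compound 4 cannot be read, as both ends are limits. This position now offers little readable contrast, with most of the series at one limit: the limit of > 100000 nM in this assay, at which 3 of the 4 values shown sit.

This single change removes a chloro and adds a ring nitrogen, and the compounds shown cannot separate the two. As far as these compounds go, whether an amine or a carboxylic acid on this ring would give a clearly lower number remains open.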